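The compounds below may be only part of what the source reports. "The series", "measured", "known", "first", "only" and "open" are said of these compounds alone.

Compound 1 `CCn1ncc(OCc2nnc(-c3ccccc3)o2)c(Cl)c1=O` is the starting point of this comparison. In a functional assay on the whole organism for inhibition, with Mythimna separata as the target, with a stated time of 5 days (on this read-out lower numbers stand for an effect already at smaller amounts and higher numbers for an effect only at larger amounts of compound), compound 1 gives only a limit, > 300 ug/mL, and not a measured number. Compound 2 `CCn1ncc(OCc2nnc(-c3ccc(F)cc3)o2)c(Cl)c1=O` carries a fluoro in place of a hydrogen on an aromatic carbon; in this assay compound 2 likewise gives only a limit, > 300 ug/mL. The step that the two limits leave unreadable from compound 1 to compound 2 therefore cannot be read, since the limit of > 300 ug/mL in this assay, at which 2 of the 3 values shown sit, holds both of these compounds. For the measured compounds named here, compound 3 `CC(C)(C)n1ncc(OCc2nnc(-c3ccc(Cl)cc3Cl)o2)c(Cl)c1=O` differs from compound 1 in more than one place, and in this assay compound 3 gives 27.8 ug/mL; no single step connects it to compound 1, so its value shows only that a measured number can occur. Compound 4 `O=c1c(Cl)c(OCc2nnc(-c3ccccc3)o2)cnn1-c1ccccc1` differs from compound 1 by phenyl in place of ethyl on an aromatic nitrogen. Going by the values given here, no measured step involves this change, and the one measured step is unreadable. For compound 4 the expected step of an at least 1.2-fold lower number from compound 1 to compound 4 (0.07 log units; that floor lies within the scatter) is one that may well stay at the limit. Compound 4 is estimated at 250 ug/mL, within 50 ug/mL to 1000 ug/mL.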

Compound 4, half-maximal effective concentration: 91.5 ug/mL
Compound 4: middle estimate off by 2.7-fold (0.44 log units), on the high side; the measured number falls inside the stated range.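

In this assay, phenyl in place of ethyl on this aromatic nitrogen gives an at least 3.2-fold lower number from compound 1 to compound 4 (0.51 log units; beyond the scatter). Among the compounds shown, this is the only single change that can be read, and it shows that the group on this nitrogen can bring the series from a limit to a measured number, whereas the step to the fluoro compound 2 cannot be read. Compound 1 gives only a limit, so this step has a floor but no known full size: the limit of > 300 ug/mL in this assay, at which 2 of the 4 values shown sit.

From the compounds shown here alone, only ethyl and phenyl are compared directly here, so it stays open whether the aromatic ring or simply the added carbon atoms matter, which a cyclohexyl or benzyl group on this nitrogen could help to separate. Going by these compounds, it is also open whether a methoxy group on the new phenyl ring would shift the number further.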